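A few compounds are considered here, and "the series" means these few. Any claim that something is new, unique, unknown or untested is made for them only; others in the source may bear on it.

Measured compounds:
Compound 1 `Cc1ccc2[nH]c(C(=O)N[C@H]3CCN(S(=O)(=O)c4ccccc4)C[C@@H]3C(=O)NCCN(C)C)cc2c1` gives 16 uL/min in an ADME assay on cells (Hepatocyte, Rattus norvegicus) for metabolic stability; a lower number here means slower removal, a higher number faster removal of the compound.
Compound 2 `Cc1ccc2[nH]c(C(=O)N[C@H]3CCN(S(=O)(=O)N4CCOCC4)C[C@@H]3C(=O)NCCN(C)C)cc2c1` gives 6 uL/min in this assay.

Within this pair, compound 2 holds the lower of the two numbers in this assay, its nearest neighbour being compound 1, and the only change between them on the sulfonyl sulfur brought a 2.7-fold lower number from compound 1 to compound 2 (0.43 log units; beyond the scatter). Compound 3 `Cc1ccc2[nH]c(C(=O)N[C@H]3CCN(S(=O)(=O)N(C)C)C[C@@H]3C(=O)NCCN(C)C)cc2c1` has not yet been measured. It differs from compound 2 by dimethylamino in place of morpholin-4-yl on a sulfonyl sulfur. Among the compounds with values here, no measured step covers this particular exchange; the single step that exists concerns the same sulfonyl sulfur but a different group, so it shows only that a change at this position can shift the number modestly. With so little to go on, compound 3 is expected to stay near compound 2, with an estimated step of a 1.2-fold higher number from compound 2 to compound 3 (0.07 log units; within the scatter), not beyond the scatter. Compound 3 is therefore estimated at 7 uL/min, within a range from 3.5 uL/min to 14 uL/min.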

Compound 3, intrinsic clearance in a liver preparation (reported as CLH), per the amount of preparation that the assay uses in the Hepatocyte assay: 10 uL/min
Beside the measured number, compound 3's estimate is 1.4-fold (0.15 log units) below it, within the range that was stated.
By their numbers in the Hepatocyte assay, from the lowest: compounds 2, 3 and 1 (each within the scatter of the next, the first and the last beyond it).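

In the Hepatocyte assay, dimethylamino, which carries no ring, cannot be told apart from morpholin-4-yl (a 1.7-fold higher number from compound 2 to compound 3 (0.22 log units; within the scatter)) or from phenyl (a 1.6-fold lower number from compound 1 to compound 3 (0.20 log units; within the scatter)), so compound 3 lies within the scatter of two compounds that stand beyond the scatter of each other. In a physicochemical assay for lipophilicity, measured as octanol-water partition, at pH 7.4 (on this read-out lower numbers stand for lower lipophilicity and higher numbers for higher lipophilicity), compound 2 gives 1 and compound 3 gives 1.2, and this exchange also stays inside the usual spread (a number 0.20 log units higher from compound 2 to compound 3 (within the scatter)). No information is available that would explain the numbers at this position.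

Within the data shown here, with only three groups on the sulfonyl sulfur, no trend across them can be drawn. Going by these compounds, it remains open how diethylamino, a piperidin-1-yl ring or a simple methyl group on that sulfur would behave in either assay.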